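The source may report more compounds than this note shows. Statements on the series, on what has been measured and on what is new or still open speak of the compounds shown alone.

Measured so far in a functional assay on the whole organism (strain Wistar) for inhibition, with Rattus norvegicus as the target, read by paw edema, with stated times of 30 min and 60 min, at a dose of 50 mg/kg by the oral route; a lower number here means less inhibition, a higher number more inhibition at the dose given (going by the name of the read-out):
- compound 1, `Cc1ccc(C2=NN(c3ccc([N+](=O)[O-])cc3)C(c3cn(-c4ccccc4)nc3-c3ccc(Cl)c(Cl)c3)C2)cc1`, gives 72.5%
- compound 2, `CC(=O)N1N=C(c2ccc(C)cc2)CC1c1cn(-c2ccccc2)nc1-c1ccc(Cl)c(Cl)c1`, gives 59.5%
- compound 3, `CC(=O)N1N=C(c2ccc(F)cc2)CC1c1cn(-c2ccccc2)nc1-c1ccc(Cl)c(Cl)c1`, gives 59.5%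

Compound 2 and compound 3 agree at the digits shown, and compound 2 sits a number 13 percentage points lower from compound 1 to compound 2 (beyond the scatter). Compound 4, `Cc1ccc(C2=NN(C=O)C(c3cn(-c4ccccc4)nc3-c3ccc(Cl)c(Cl)c3)C2)cc1`, differs from compound 2 by a single change: hydrogen in place of methyl on a carbonyl carbon. Within the data shown here, two steps bear on it. Swapping the ring substituent gave no change at the digits printed from compound 2 to compound 3 (within the scatter), while replacing the whole group on the ring nitrogen gave a number 13 percentage points lower from compound 1 to compound 2 (beyond the scatter). Trimming one carbon from that same group is a far smaller alteration than the one in the second step, so no step beyond the scatter is expected here. The expected step is a number 2.5 percentage points lower from compound 2 to compound 4 (within the scatter). Compound 4 is therefore estimated at 57%, with a range from 45% to 70%.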

Compound 4, a percentage reported as inhibition, in the whole organism at one dose (the size of the read-out at that dose, not a potency): 53.4%
Compound 4: middle estimate off by 3.6 percentage points, on the high side; the range from low to high includes it.
By their numbers in this assay, from the lowest: compounds 4, 2 and 3 (each within the scatter of the next); then compound 1.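

In this assay going from acetyl to formyl gives a number 6.1 percentage points lower from compound 2 to compound 4 (within the scatter) and so the methyl on this carbonyl carbon can be lost without a step beyond the scatter. Formyl, like acetyl, falls short of 4-nitrophenyl on the ring nitrogen, with a number 19.1 percentage points lower from compound 1 to compound 4 (beyond the scatter) in the same direction as the acetyl step. Nothing measured here explains either step.

As far as these compounds go, whether a longer chain on the carbonyl, such as propanoyl, or an amine in that place would hold this level stays open. So does whether a plain phenyl on the ring nitrogen would match 4-nitrophenyl.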